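Swapping the aminophenyl ketone for a dimethoxyphenyl ketone

A few compounds are considered here, and "the series" means these few. Any claim that something is new, unique, unknown or untested is made for them only; others in the source may bear on it.

Compound 1 `COc1cc(-c2cc(/C=C/C(=O)c3ccc(N)cc3)[nH]n2)cc(OC)c1OC`: 6000 nM
Compound 2 `COc1ccc(-c2cc(/C=C/C(=O)c3cc(OC)c(OC)c(OC)c3)[nH]n2)cc1OC`: 5290 nM

Of the compounds shown here, two have been measured in a functional assay on UO-31 cells (Homo sapiens) for inhibition, read by sulforhodamine B assay, with a stated time of 48 h; a lower number here means that less compound is tolerated, a higher number that more compound is tolerated. Compound 1 gives 6000 nM and compound 2 gives 5290 nM, and the two numbers lie within the usual scatter of each other, so neither can be placed ahead of the other. Both share a core carrying methoxylated phenyl rings on either end of an unsaturated ketone; compound 1 bears a 4-aminophenyl on its carbonyl carbon, while compound 2 bears a 3,4-dimethoxyphenyl on the pyrazole and a 3,4,5-trimethoxyphenyl on the carbonyl carbon.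

Compound 3 `COc1ccc(C(=O)/C=C/c2cc(-c3cc(OC)c(OC)c(OC)c3)n[nH]2)cc1OC` has not yet been measured. Compared with compound 1, the change is 3,4-dimethoxyphenyl in place of 4-aminophenyl on a carbonyl carbon. Compound 3 thus combines the carbonyl-side dimethoxyphenyl pattern of compound 2 with the pyrazole-side trimethoxyphenyl of compound 1. Because compound 1 gives 6000 nM and compound 2 gives 5290 nM, values within the scatter of each other, the step from compound 1 to compound 3 is expected to be small, within the scatter, with no clear direction: a 1.1-fold lower number from compound 1 to compound 3 (0.04 log units; within the scatter). Compound 3 is therefore estimated at 5500 nM, in a range from 2500 nM to 12000 nM.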

Compound 3, concentration lethal to 50% of the cells: 5170 nM
Compound 3: middle estimate off by 1.1-fold (0.03 log units), on the high side; the range from low to high includes it.
By their numbers in this assay, from the lowest: compounds 3, 2 and 1 (each within the scatter of the next).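

In this assay, within the data shown here, 3,4-dimethoxyphenyl in place of 4-aminophenyl on a carbonyl carbon gives a 1.2-fold lower number from compound 1 to compound 3 (0.06 log units; within the scatter) and provides the first reading of a change in this one place. The exchange takes away the hydrogen-bond donor of the 4-aminophenyl and brings in more heavy atoms and more hydrogen-bond acceptors, yet the read-out does not separate the two compounds, so this pair shows that the two groups cannot be told apart here. Nothing available here accounts for the two groups reading alike.

From the compounds shown here alone, whether a group of another kind on this carbonyl carbon, such as a carboxylic acid, a nitrile or a longer chain, would give a step beyond the scatter remains open. Going by these compounds, it also remains open whether 3,4-dimethoxyphenyl and 4-aminophenyl would still read alike if the rest of the shared core were changed, for instance with a 4-methoxyphenyl group in place of the trimethoxyphenyl group that compound 1 and compound 3 both carry.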